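A few compounds are considered here, and "the series" means these few. Any claim that something is new, unique, unknown or untested is made for them only; others in the source may bear on it.

Measured compounds:
compound 1 `O=c1oc2ccc(Br)cc2c(=O)n1-c1ccc(I)cc1F`, 7900 nM
compound 2 `O=c1oc2ccc(F)cc2c(=O)n1-c1ccc(I)cc1F`, 6000 nM
compound 3 `O=C(Nc1ccc(I)cc1F)c1cc(F)ccc1O`, 7400 nM

In an ADME assay on RAW264.7 cells (Mus musculus) for cytotoxicity, read by MTT assay, with a stated time of 24 h (a lower number here means that less compound is tolerated, a higher number that more compound is tolerated), compound 2 gives 6000 nM and compound 1 gives 7900 nM; the change between them is bromo in place of fluoro on an aromatic carbon and it made a 1.3-fold higher number from compound 2 to compound 1 (0.12 log units; within the scatter). Compound 3, built on a different core, gives 7400 nM; the difference between the two cores is not broken down here. Compound 4 `O=C(Nc1ccc(I)cc1F)c1cc(Br)ccc1O` is not yet measured. From compound 3 to compound 4 the change is bromo in place of fluoro on an aromatic carbon, the same kind of change as from compound 2 to compound 1, but the place differs: here the aromatic carbon is meta to a large group and para to a hydroxy group, there it was part of a fused system of two rings, meta and para to a fused ring. Beside the earlier step, the step of a 1.1-fold higher number from compound 3 to compound 4 (0.06 log units; within the scatter) in this assay is expected to be of similar size, resting on compound 3 at 7400 nM and the step of a 1.3-fold higher number from compound 2 to compound 1 (0.12 log units; within the scatter). Compound 4 is therefore estimated at 8500 nM, between 4500 nM and 16000 nM.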

Compound 4, half-maximal cytotoxic concentration: 6400 nM
Compound 4: the middle estimate sits 1.3-fold (0.12 log units) above what was measured, and the stated range covers the measured number.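

In this assay, bromo in place of fluoro on an aromatic carbon gives a 1.2-fold lower number from compound 3 to compound 4 (0.06 log units; within the scatter). Set beside the same change on the other core, the two steps cannot be told apart: the same change on two cores in this assay, a 1.3-fold higher number (0.12 log units; within the scatter) from compound 2 to compound 1 and a 1.2-fold lower number (0.06 log units; within the scatter) from compound 3 to compound 4, 1.5-fold (0.18 log units) apart, within the scatter of two such steps. This shows that the change leaves the number within the scatter on both cores, but not that a step of real size would carry from one core to the other, as neither step rises above the scatter.

The compounds shown leave open whether a chloro, methoxy or amine group at that aromatic carbon would shift the number on either core. Also open, going by these compounds, is what follows when the iodo group, present in all four compounds, gives way to a nitrile.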